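The source may hold more compounds than are shown below. What is called first, only, known or untested is meant among the compounds shown, and "the series" means these compounds.

In a functional assay on cells for positive allosteric modulation of metabotropic glutamate receptor 2 (Homo sapiens), read by scintillation counting and GTPgammaS binding, with a stated time of 30 min (on this read-out lower numbers stand for an effect already at smaller amounts and higher numbers for an effect only at larger amounts of compound), compound 1 `Cc1cc(Oc2ccc(-c3ccn4c(CC5CC5)nnc4c3Cl)cc2F)ccn1` gives 251 nM.
Compound 2 `CC(C)Nc1ccc(-c2ccn3c(CC4CC4)nnc3c2Cl)cc1F` gives 224 nM.
Compound 3 `CC(C)Nc1ccc(-c2ccn3c(CC4CC4)nnc3c2C(F)(F)F)cc1F` gives 93.3 nM.

Compound 2 holds the second highest number of the three. Its nearest neighbour is compound 1, with a 1.1-fold lower number from compound 1 to compound 2 (0.05 log units; within the scatter); its furthest is compound 3, with a 2.4-fold lower number from compound 2 to compound 3 (0.38 log units; beyond the scatter). Compound 4 `Fc1cc(-c2ccn3c(CC4CC4)nnc3c2Cl)ccc1NC1CC1` differs from compound 2 in one place: cyclopropyl in place of isopropyl on a nitrogen on an aromatic ring. Among the measured compounds shown here, no measured step matches this change. The step of a 1.1-fold lower number from compound 1 to compound 2 (0.05 log units; within the scatter) exchanged the entire isopropylamino for (2-methylpyridin-4-yl)oxy and stayed within the scatter, while a 2.4-fold lower number from compound 2 to compound 3 (0.38 log units; beyond the scatter) altered a group on the shared core instead. The expected step is therefore a 1.0-fold higher number from compound 2 to compound 4 (0.01 log units; within the scatter), not beyond the scatter. Compound 4 is estimated at 230 nM, within a range of 100 nM to 520 nM.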

Compound 4, half-maximal effective concentration: 63.1 nM
Estimate against measurement, compound 4: 3.6-fold (0.56 log units) above; measured number below the stated range.
By their numbers in this assay, from the lowest: compounds 4 and 3 (each within the scatter of the next); then compounds 2 and 1 (each within the scatter of the next).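

Swapping isopropyl for cyclopropyl on a nitrogen on an aromatic ring keeps the same count of heavy atoms and adds one ring, yet it gives a 3.5-fold lower number from compound 2 to compound 4 (0.55 log units; beyond the scatter), so the group on this nitrogen matters even in so small a change. Cyclopropylamino also stands clear of (2-methylpyridin-4-yl)oxy, with a 4.0-fold lower number from compound 1 to compound 4 (0.60 log units; beyond the scatter), whereas isopropylamino stayed within the scatter of it. Nothing measured here explains this difference. From the compounds shown here alone, it remains open whether a cyclobutyl on the same nitrogen would follow cyclopropyl, and whether cyclopropylamino combines with trifluoromethyl on the shared core.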